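A longer hydroxyalkyl chain on the shared core

The source may report more compounds than this note shows. Statements on the series, on what has been measured and on what is new or still open speak of the compounds shown alone.

Of the compounds shown here, three built on one shared core have been tested in a functional assay on SW-620 cells (Homo sapiens) for inhibition, read by MTT assay, with a stated time of 72 h; a lower number here means a stronger inhibitor, a higher number a weaker inhibitor. Compound 1 `O=c1cc(Cn2cc(C3CC3)nn2)c2ccc(O)cc2o1` carries a cyclopropyl group on an aromatic carbon of the five-membered aromatic ring with 3 nitrogen. In this assay compound 1 gives only a limit, > 100000 nM. Compound 2 `O=c1cc(Cn2cc(CCO)nn2)c2ccc(O)cc2o1` carries a 2-hydroxyethyl group in that place. In this assay compound 2 likewise reaches only a limit, > 100000 nM. Compound 3 `CC(O)c1cn(Cc2cc(=O)oc3cc(O)ccc23)nn1` carries a 1-hydroxyethyl group. For compound 3 this assay again records a limit, > 100000 nM. Because all three values sit at one limit (the limit of > 100000 nM in this assay, at which 3 of the 3 values shown sit), none of the steps among them can be read: a step that the two limits leave unreadable from compound 1 to compound 2, a step that the two limits leave unreadable from compound 1 to compound 3 and a step that the two limits leave unreadable from compound 2 to compound 3 are all of unreadable size. Compound 3 thus stands at the limit alongside the other two, with no number that would place it higher or lower.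

Compound 4 `O=c1cc(Cn2cc(CCCO)nn2)c2ccc(O)cc2o1` differs from compound 3 in one place: 3-hydroxypropyl in place of 1-hydroxyethyl on an aromatic carbon. Among the compounds with values here, none of the measured steps shows a change of the hydroxyalkyl group moving a value off the limit, so no step beyond the scatter is expected in this assay. Compound 4 is therefore expected to give 100000 nM, within 40000 nM to 300000 nM, most probably again as a limit. The step from compound 3 to compound 4 is estimated as a number no higher from compound 3 to compound 4 (the limit leaves the size open).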

Compound 4, half-maximal inhibitory concentration: > 100000 nM
Compound 4: no number, only a limit; the forecaster's own chance of this, stated with the estimate: 85%; the middle value lies on the limit itself.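

Compound 4 also gives only a limit in this assay, > 100000 nM. No step from compound 1, compound 2 or compound 3 to compound 4 can be read, because all the values sit at one limit: the limit of > 100000 nM in this assay, at which 4 of the 4 values shown sit.

The compounds shown leave open how the four rank in this assay and whether changing this group affects the value at all.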